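The source may hold more compounds than are shown below. What is called first, only, known or untested is meant among the compounds shown, and "the series" means these compounds.

Measured in a functional assay, read by spectrophotometry, with a stated time of 3 min; a lower number here means a stronger inhibitor, a higher number a weaker inhibitor:
compound 1 `O=c1cc(/C=N\c2ccc(O)cc2)c2ccc(OCc3ccccc3)cc2o1`: 64500 nM
compound 2 `Nc1ccccc1/N=C\c1cc(=O)oc2cc(OCc3ccccc3)ccc12`: 9250 nM
compound 3 `O=c1cc(/C=N\O)c2ccc(OCc3ccccc3)cc2o1`: 22800 nM

Compound 3 holds the middle place among the three numbers in this assay, with a 2.5-fold higher number from compound 2 to compound 3 (0.39 log units; beyond the scatter) and a 2.8-fold lower number from compound 1 to compound 3 (0.45 log units; beyond the scatter).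

Compound 4 `O=c1cc(-c2nc3ccccc3[nH]2)c2ccc(OCc3ccccc3)cc2o1` is not yet measured. It carries 1H-benzimidazol-2-yl on an aromatic carbon, opposite the ring oxygen: a group of 9 heavy atoms (7 carbon, 2 nitrogen; one five-membered aromatic ring with 2 hetero atoms, one six-membered aromatic ring of carbon only) in place of a group of 3 heavy atoms (1 carbon, 1 nitrogen, 1 oxygen; no ring), on an aromatic carbon.

Among the compounds with values here, no measured step makes this replacement. The nearest evidence is the exchange of groups on the double-bonded nitrogen, and all of those steps are modest. Two aryl-bearing compounds give conflicting guidance: compound 2 gives the lowest number, with a 7.0-fold lower number from compound 1 to compound 2 (0.84 log units; beyond the scatter), whereas compound 1 gives the highest. An aromatic ring in the new group therefore does not set the direction. Only a modest shift is expected, leaning slightly lower on the evidence of a 2.5-fold higher number from compound 2 to compound 3 (0.39 log units; beyond the scatter), and possibly none beyond the scatter.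

The estimated step is a 1.5-fold lower number from compound 3 to compound 4 (0.18 log units; within the scatter).

For compound 4 the expected value is 15000 nM, with an estimated range from 4500 nM to 50000 nM.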

Compound 4, half-maximal inhibitory concentration: "not active" (no number reported)
For compound 4 the study gives words and no number, so the estimate cannot be set against anything.
By their numbers in this assay, from the lowest: compound 2; then compound 3; then compound 1.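

Within the data shown here, compound 4 is reported only as "not active" in this assay with no number, so no step from compound 3 to compound 4 can be read. No measured evidence bears on this result. The compounds shown leave open how much weaker compound 4 is than compound 3, if at all.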